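Nitro for methyl on the benzyl arm: working notes

The source may report more compounds than this note shows. Statements on the series, on what has been measured and on what is new or still open speak of the compounds shown alone.

Measured compounds in a functional assay on NIH3T3 cells (Mus musculus); a lower number here means that less compound is needed, a higher number that more compound is needed for the effect:
Compound 1 `COC(=O)[C@H](CCSC)NC(=O)c1ccc(NCc2cncn2Cc2ccccc2C)cc1-c1ccccc1` gives > 10 uM, a limit of the assay.
Compound 2 `CSCC[C@H](NC(=O)c1ccc(CNCc2[nH]cnc2C)cc1-c1ccccc1C)C(=O)O` gives > 10 uM, likewise a limit.
Compound 3 `CSCC[C@H](NC(=O)c1ccc(CNCc2c[nH]cn2)cc1-c1ccccc1C)C(=O)OC(C)C` gives 10 uM.

Compound 1 stands at the limit of > 10 uM in this assay, at which 2 of the 3 values shown sit, so for it no number is known, only that the concentration for half-maximal effect was not reached within the tested range. Among the compounds with values here, compound 3 is the only member of the set with a number, and compounds 2 and 3 differ from compound 1 in several places at once, so none of the measured pairs isolates a single change.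

The next compound, compound 4 `COC(=O)[C@H](CCSC)NC(=O)c1ccc(NCc2cncn2Cc2ccc([N+](=O)[O-])cc2)cc1-c1ccccc1`, differs from compound 1 by 4-nitrophenyl in place of 2-methylphenyl on a saturated chain carbon bound to an aromatic nitrogen. Within the data shown here, no measured pair in this assay carries this change, so the set gives no direction for it. With compound 1 already at a limit, and with the set otherwise flat at or near the same limit, the expected step from compound 1 to compound 4 is a step that the limit leaves unreadable from compound 1 to compound 4, that is nothing beyond the scatter, because compound 1 sits at the limit of > 10 uM in this assay, at which 2 of the 3 values shown sit. Compound 4 is accordingly estimated at 15 uM, with a range from 5 uM to 50 uM, and it is expected that this assay will again report a limit rather than a number.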

Compound 4, concentration for half-maximal effect: > 10 uM
Compound 4 ended at the assay's limit (the forecaster's own chance of this, stated with the estimate: 70%); the middle value is on the limit's open side.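

Compound 1 and compound 4 both stand at a limit rather than a number, so no step can be read for the change from 2-methylbenzyl to 4-nitrobenzyl: the limit of > 10 uM in this assay, at which 3 of the 4 values shown sit.

The compounds shown leave open whether any group on this benzyl arm brings the core of compound 1 to a number rather than a limit.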